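Five-Membered Ring Exchange at the Para-to-Hydroxy Position

This account rests on a few compounds, and the source may have more. Where it says the series, first, only, none or still open, it means among the compounds named here.

Going by the values given here, compound 1 `O=C(O)c1cc(C2N=NN=N2)ccc1O` is the single measured number in the set. In a functional assay on the whole organism for inhibition, with Rattus norvegicus as the target, read by paw edema (a higher number here means that more compound is needed for the effect, a lower number that less compound is needed), compound 1 gives 110 mg/kg. Compound 2 `O=C(O)c1cc(-c2ccncn2)ccc1O` carries a limit rather than a number. In this assay compound 2 returns > 200 mg/kg, which is a limit of the assay and not a value. Of the two results shown, the evidence reads as the limit of > 200 mg/kg in this assay, at which 1 of the 2 values shown sits. Among the compounds with values here, no step between two measured compounds that differ in a single place is available, so nothing in the data shows how far a change at this ring position moves the read-out.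

Compound 3 `O=C(O)c1cc(-n2cccn2)ccc1O` has not been measured. It differs from compound 1 by a group of 5 heavy atoms (3 carbon, 2 nitrogen; one five-membered aromatic ring with 2 hetero atoms) in place of a group of 5 heavy atoms (1 carbon, 4 nitrogen; one five-membered non-aromatic ring with 4 hetero atoms), on an aromatic carbon. The change sits on an aromatic carbon of the six-membered ring of carbon only, meta to the carboxy group and para to the hydroxy group.

Within the data shown here, with no measured step to lean on, the step expected is a 1.6-fold higher number from compound 1 to compound 3 (0.21 log units; within the scatter), a modest shift toward needing more compound, with a real chance that only a limit is returned. Compound 3 is estimated at 180 mg/kg, within 90 mg/kg to 400 mg/kg.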

Compound 3, dose for half-maximal effect: 200 mg/kg
The estimate for compound 3 lay 1.1-fold (0.05 log units) below the measured number; low and high end bracket the measured number.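

In this assay the position para to a hydroxy group now has its first measured step, a 1.8-fold higher number from compound 1 to compound 3 (0.26 log units; within the scatter), so 1H-pyrazol-1-yl in place of the five-membered non-aromatic ring with 4 hetero atoms cannot be told apart from repeat measurement on this pair. The exchange keeps the group at 5 heavy atoms and goes from 4 hydrogen-bond acceptors to 2, and this one pair shows no change in the read-out beyond the scatter for that exchange. Compound 2 carries a limit and not a number, so steps to it cannot be read: the limit of > 200 mg/kg in this assay, at which 1 of the 3 values shown sits.

From the compounds shown here alone, whether a group of another kind on this aromatic carbon, such as an amine, a carboxylic acid or a longer chain, would give a step beyond the scatter stays open. All compounds shown keep the carboxy group and the hydroxy group of the shared core unchanged, so the effect of a change at either of those places on the dose in the paw edema read-out also stays open.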